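This account rests on a few compounds, and the source may have more. Where it says the series, first, only, none or still open, it means among the compounds named here.

Among the three measured compounds, compound 3 `Cc1cccc(-c2onc3ccc(/C=C/C(=O)O)cc23)c1` gives the lowest number in an assay for inhibition of inositol hexakisphosphate kinase 2 (Homo sapiens), read by colorimetric assay, coupled enzyme assay and malachite green, with a stated time of 120 min, in the presence of a further agent that is not named here (on this read-out higher numbers stand for weaker inhibition and lower numbers for stronger inhibition), at 290 nM. Within the data shown here, compound 2 `Cc1ccc(-c2onc3ccc(/C=C/C(=O)O)cc23)cc1` gives 6510 nM, and the only measured single-point step, a 22-fold lower number from compound 2 to compound 3 (1.35 log units; beyond the scatter), concerns where the methyl sits and not the acid-bearing chain. Compound 1 `CN(C)C(=O)/C=C/c1ccc2noc(-c3ccccc3)c2c1` gives 40300 nM, but it differs from the others in more than one place, so its number cannot be tied to one change. Compound 4 `Cc1cccc(-c2onc3ccc(C(=O)O)cc23)c1` has not been tested; it keeps the core of compound 3 with one change: carboxy in place of 2-carboxyethenyl on an aromatic carbon. Among the measured compounds shown here, no measured step touches this change, so the direction is unknown. Compound 4 is estimated at 1500 nM, within 250 nM to 9000 nM, and the expected step is a 5.2-fold higher number from compound 3 to compound 4 (0.71 log units; beyond the scatter).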

Compound 4, half-maximal inhibitory concentration: 150 nM
For compound 4 the middle estimate is 10-fold (1.00 log units) above the measured one; measured number outside the range, below it.
By their numbers in this assay, from the lowest: compounds 4 and 3 (each within the scatter of the next); then compound 2; then compound 1.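

In this assay the shorter carboxy can take the place of the 2-carboxyethenyl chain at this position, with a 1.9-fold lower number from compound 3 to compound 4 (0.29 log units; within the scatter). On the core of compound 3, then, the chain's carbon-carbon double bond is not needed to keep the number this low. Nothing available here explains why the two groups read alike. On these data alone, whether the same holds alongside the 4-methylphenyl of compound 2 remains open. So does what an amine, or a longer chain ending in carboxy, would give at this position.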